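Tetrazole Isomer Swap and Liver Stability of Biphenyl Ethers

The source may hold more compounds than are shown below. What is called first, only, known or untested is meant among the compounds shown, and "the series" means these compounds.

Compound 1 `CC(C(=O)COc1ccc(-c2ccccc2)cc1)n1cnnn1` and compound 2 `CC(C(=O)COc1ccc(-c2ccccc2)cc1)n1ncnn1` share one core, while compound 3 `CC(Oc1ccc(-c2ccccc2)cc1)C(=O)Cn1cnnn1` and compound 4 `CC(Oc1ccc(-c2ccccc2)cc1)C(=O)Cn1ncnn1` share another; the difference between the two cores is not broken down here. In an ADME assay on S9 fraction from liver (Rattus norvegicus) for metabolic stability, read by HPLC, using NADPH, with a stated time of 30 min (a higher number here means that more of the compound is left, a lower number that less of the compound is left), compound 1 gives 11% and compound 2 gives 0%, a step of a number 11 percentage points lower from compound 1 to compound 2 (beyond the scatter) for the change (2H-tetrazol-2-yl in place of 1H-tetrazol-1-yl on a saturated chain carbon bound to a carbonyl carbon and a saturated chain carbon). In this assay compound 3 gives 9%, a number within the scatter of compound 1. Compound 4 carries the same kind of change, (2H-tetrazol-2-yl in place of 1H-tetrazol-1-yl on a saturated chain carbon bound to a carbonyl carbon); around the place, the saturated chain carbon in compound 3 is bound to a carbonyl carbon, whereas in compound 1 it is bound to a carbonyl carbon and a saturated chain carbon. The step is expected to be a number 8 percentage points lower from compound 3 to compound 4 (within the scatter), close in size to the earlier one, because the measured pair showed a number 11 percentage points lower from compound 1 to compound 2 (beyond the scatter). Compound 4 is therefore estimated at 1%, between 0% and 8%.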

Compound 4, percent of the compound remaining in the Rattus norvegicus assay: 0%
Compound 4: middle estimate off by 1 percentage points, on the high side, within the range that was stated.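

In the Rattus norvegicus assay, placing 2H-tetrazol-2-yl where 1H-tetrazol-1-yl stood on the core of compound 3 gives a number 9 percentage points lower from compound 3 to compound 4 (within the scatter), with compound 3 at 9% and compound 4 at 0%. Set beside the same change on the core of compound 1, this step does not differ from it: the same change on two cores in the Rattus norvegicus assay, a number 11 percentage points lower (beyond the scatter) from compound 1 to compound 2 and a number 9 percentage points lower (within the scatter) from compound 3 to compound 4, 2 percentage points apart, within the scatter of two such steps This agreement suggests that the change carries from one of these cores to the other, but that step taken alone stays within the scatter, and two cores cannot show that the change behaves alike across the wider series.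

The compounds shown leave open whether the step holds on a core bearing an amine or a carboxylic acid. They also leave open whether, in a physicochemical assay for solubility, read by HPLC, measured as thermodynamic solubility, with stated times of 10 min and 24 h, at 20 degrees C, at pH 7.4 (a higher number here means a more soluble compound, a lower number a less soluble compound), the step of a 2.0-fold lower number from compound 3 to compound 4 (0.30 log units; within the scatter) repeats on the core of compound 1. In the physicochemical assay compound 3 gives 4 ug/mL and compound 4 gives 2 ug/mL.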